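Acylguanidine series: imidazolyl in place of pyrrolidinyl

This account rests on a few compounds, and the source may have more. Where it says the series, first, only, none or still open, it means among the compounds named here.

Going by the values given here, compound 2 `Cc1cc(N2CCCC2)c(S(C)(=O)=O)cc1C(=O)N=C(N)N` gives 11 nM in a functional assay for inhibition of sodium/hydrogen exchanger (Oryctolagus cuniculus) (on this read-out higher numbers stand for weaker inhibition and lower numbers for stronger inhibition), the higher of the two numbers so far; compound 1 `CCCSc1cc(C)c(C(=O)N=C(N)N)cc1S(C)(=O)=O` gives 6.8 nM, and the step of a 1.6-fold higher number from compound 1 to compound 2 (0.21 log units; within the scatter) lies within the scatter. Compound 3 `Cc1cc(-n2ccnc2)c(S(C)(=O)=O)cc1C(=O)N=C(N)N` carries the change (1H-imidazol-1-yl in place of pyrrolidin-1-yl on an aromatic carbon). Among the compounds with values here, only one measured step bears on a change of the group at this place, namely a 1.6-fold higher number from compound 1 to compound 2 (0.21 log units; within the scatter), and it shows no movement beyond the scatter; a similarly small step is therefore expected for compound 3, perhaps slightly upward, as a 1.8-fold higher number from compound 2 to compound 3 (0.26 log units; within the scatter). Compound 3 is estimated at 20 nM in this assay, within 5 nM to 80 nM.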

Compound 3, half-maximal inhibitory concentration: 23 nM
Compound 3: middle estimate off by 1.2-fold (0.06 log units), on the low side; measured number inside the range.
By their numbers in this assay, from the lowest: compounds 1 and 2 (each within the scatter of the next); then compound 3.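

In this assay, going by these compounds alone, the aromatic 1H-imidazol-1-yl gives the first step at this position that lies beyond the scatter, with a 2.1-fold higher number from compound 2 to compound 3 (0.32 log units; beyond the scatter) and also a 3.4-fold higher number from compound 1 to compound 3 (0.53 log units; beyond the scatter) as modest rises. The place on the aromatic carbon ortho to the methylsulfonyl group therefore does not treat all groups alike, although propylsulfanyl and pyrrolidin-1-yl stay within the scatter of each other. Nothing at hand gives a reason for this difference. Still open, from the compounds shown here alone, is whether 1H-pyrrol-1-yl, or a simple amine such as dimethylamino, would fall with compound 2 or with compound 3.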